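A Second Methoxy Group on a Weak Cytotoxic Series

The source may report more compounds than this note shows. Statements on the series, on what has been measured and on what is new or still open speak of the compounds shown alone.

Measured in a functional assay on A549 cells (Homo sapiens) for cytotoxicity, read by MTT assay, with a stated time of 72 h; on this read-out lower numbers stand for stronger inhibition and higher numbers for weaker inhibition:
- compound 1 (`COc1ccc(OC)c(/C=C/C(=O)Nc2cc3c(Nc4ccc(F)c(Cl)c4)ncnc3cc2OC)c1`): 11200 nM
- compound 2 (`COc1ccc(/C=C/C(=O)Nc2cc3c(Nc4ccc(F)c(Cl)c4)ncnc3cc2OC)cc1`): "not active" (no number reported)
- compound 3 (`N#Cc1ccc(/C=C/C(=O)Nc2cc3c(Nc4ccc(F)c(Cl)c4)ncnc3cc2O[C@H]2CCOC2)cc1`): "not active" (no number reported)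

Among the measured compounds shown here, only one of these three compounds has a number. Compound 2 has no single value on this scale, since compound 2 is recorded as "not active" (no number reported) in this assay. Compound 3 is the one further entry of this kind, so compound 2 cannot be ranked precisely against it.

Compound 4 (`COc1ccc(/C=C/C(=O)Nc2cc3c(Nc4ccc(F)c(Cl)c4)ncnc3cc2OC)c(OC)c1`) is built from compound 2 by one change: methoxy in place of hydrogen on an aromatic carbon. In words, this is methoxy in place of hydrogen on an aromatic carbon, ortho to a large group and meta to a methoxy group, turning 4-methoxyphenyl into 2,4-dimethoxyphenyl.

For the measured compounds named here, no measured pair shows this change on its own, so the evidence is indirect. Compound 1 also has a second methoxy group on this ring, at a different place, and compound 1 gives 11200 nM in this assay. On that basis, a small move towards stronger inhibition is expected, from no number to a weak but measurable value. Compound 4 could just as well stay without a number. If a number is reported, the estimated value for compound 4 is 20000 nM, with an expected range from 8000 nM to 50000 nM.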

Compound 4, half-maximal inhibitory concentration: 33300 nM
Estimate against measurement, compound 4: 1.7-fold (0.22 log units) below; low and high end bracket the measured number.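

In this assay compound 4 gives 33300 nM, so a methoxy group added to the 4-methoxyphenyl ring of compound 2 comes with a measurable value. The step from compound 2 cannot be read. Compound 2 has no number. Together with compound 1, this means that both dimethoxyphenyl compounds shown have a number, so a measurable value does not depend on one single arrangement of the two methoxy groups, yet the arrangement still counts: 2,4-dimethoxyphenyl in place of 2,5-dimethoxyphenyl gives a 3.0-fold higher number from compound 1 to compound 4 (0.47 log units; beyond the scatter), a modest step beyond the usual scatter. Nothing available explains this difference between the two rings.

The compounds shown leave open whether methoxy itself matters at this position or whether another group there, such as an amine, a carboxylic acid or a longer chain like butoxy, would give a similar value. They also leave open how a 2-methoxyphenyl ring, carrying only the newly added methoxy group, would compare with compound 4.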